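Fluoro in Place of Hydrogen on a Benzamido Group

A few compounds are considered here, and "the series" means these few. Any claim that something is new, unique, unknown or untested is made for them only; others in the source may bear on it.

Compound 1: `COc1cccc(-c2nn(-c3ccccc3)cc2-c2ccnc(NCCNC(=O)Nc3ccc(Cl)c(Cl)c3)c2)c1`, 5950 nM
Compound 2: `O=C(NCCCNc1cc(-c2cn(-c3ccccc3)nc2-c2cccc(O)c2)ccn1)c1ccccc1`, 3690 nM

Both compounds were tested in a functional assay on cells (Panel prostate (Carcinoma cell lines), Homo sapiens) for antiproliferative activity; a lower number here means a stronger inhibitor of growth, a higher number a weaker inhibitor of growth. Compound 1 gives 5950 nM and compound 2 gives 3690 nM; the two numbers lie within the scatter of each other, so neither compound can be set apart from the other on this evidence. Going by the values given here, they also differ from one another in more than one place, so no single step links them, and nothing beyond the two values themselves is read from the pair.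

Compound 3, `O=C(NCCCNc1cc(-c2cn(-c3ccccc3)nc2-c2cccc(O)c2)ccn1)c1ccc(F)cc1`, has not yet been measured. It differs from compound 2 in exactly one place: fluoro in place of hydrogen on an aromatic carbon. Among the compounds with values here, no pair of measured compounds shows what this kind of exchange does in this assay, so the expectation rests on compound 2 alone. A change of this size, a single fluorine added to the ring of the benzamido group, is expected to move the number little; the step is estimated as a 1.2-fold lower number from compound 2 to compound 3 (0.06 log units; within the scatter), which is no larger than the scatter, in either direction. Compound 3 is therefore expected to give about 3200 nM in this assay, with a range from 1200 nM to 9000 nM.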

Compound 3, concentration for 50% growth inhibition: 3720 nM
Compound 3: the middle estimate sits 1.2-fold (0.07 log units) below what was measured; measured number inside the range.
By their numbers in this assay, from the lowest: compounds 2, 3 and 1 (each within the scatter of the next).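

In this assay, going by these compounds alone, the exchange of hydrogen for fluoro on the ring of the benzamido group reads as a 1.0-fold higher number from compound 2 to compound 3 (0.00 log units; within the scatter) and is the first step in this set that links two measured compounds through a single place. It shows that, on this aromatic carbon para to a large group, adding a single fluorine yields a pair that cannot be told apart on this measure, so the exchange offers no sign of an effect on growth inhibition in either direction. Nothing at hand offers an explanation for this reading or ties it to any property of the fluorine.

What the compounds shown leave open is whether this place answers only to an atom as small as fluorine, or whether a larger group such as methoxy, trifluoromethyl or a dimethylamino group would also leave the number within the scatter. They also leave open whether chloro or a carboxylic acid on this ring, or a longer chain linking the benzamido group to the shared core, would set a compound apart from compound 2.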